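The source may report more compounds than this note shows. Statements on the series, on what has been measured and on what is new or still open speak of the compounds shown alone.

In an ADME assay on Vero cells (Chlorocebus sabaeus) for cytotoxicity, read by MTT assay (on this read-out higher numbers stand for weaker inhibition and lower numbers for stronger inhibition), the measured compounds are:
- compound 1 `C=CCOc1cc(OC)c(C(=O)/C=C/c2ccccc2)c(OCC=C)c1`: 17100 nM
- compound 2 `C=CCOc1cc(OC)c(C(=O)/C=C/c2cccc(OC)c2)c(OCC=C)c1`: 142000 nM
- compound 3 `C=CCOc1cc(OC)c(C(=O)/C=C/c2ccccc2F)c(OCC=C)c1`: 16300 nM

Compound 2 has the highest number of the three. Compound 4 `C=CCOc1cc(OC)c(C(=O)/C=C/c2ccncc2)c(OCC=C)c1`, not yet measured, differs from it as follows: pyridin-4-yl in place of 3-methoxyphenyl on a double-bonded chain carbon bound to a double-bonded chain carbon. Within the data shown here, no compound carrying pyridin-4-yl has been measured, so the evidence is indirect. Two measured steps involve the 3-methoxyphenyl group, an 8.3-fold higher number from compound 1 to compound 2 (0.92 log units; beyond the scatter) and an 8.7-fold lower number from compound 2 to compound 3 (0.94 log units; beyond the scatter). The third, a 1.0-fold lower number from compound 1 to compound 3 (0.02 log units; within the scatter), shows compounds 1 and 3 level. A return towards their values is therefore expected, though perhaps not all the way. The expected step is a 4.7-fold lower number from compound 2 to compound 4 (0.68 log units; beyond the scatter). For compound 4 the estimate is 30000 nM, with an expected range from 9000 nM to 110000 nM.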

Compound 4, half-maximal inhibitory concentration: 2800 nM
Compound 4: middle estimate off by 11-fold (1.03 log units), on the high side; measured number outside the range, below it.
By their numbers in this assay, from the lowest: compound 4; then compounds 3 and 1 (each within the scatter of the next); then compound 2.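

Measured in this assay the pyridin-4-yl group gives a lower number than each carbon-only ring at this position (a 51-fold lower number from compound 2 to compound 4 (1.71 log units; beyond the scatter); a 6.1-fold lower number from compound 1 to compound 4 (0.79 log units; beyond the scatter); a 5.8-fold lower number from compound 3 to compound 4 (0.77 log units; beyond the scatter)). Replacing the 3-methoxyphenyl group therefore need not stop at the level shared by compound 1 and compound 3, and a ring with a hetero atom can pass beyond it. Nothing available here accounts for this shift. As far as these compounds go, it remains open whether pyridin-3-yl or pyrimidinyl would go the same way as pyridin-4-yl, and how an aminophenyl group would compare.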